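The compounds below may be only part of what the source reports. "The series", "measured", "known", "first", "only" and "open" are said of these compounds alone.

Measured so far:
Compound 1 `CC(CNCC1CCCC1)Oc1cccc2ccc(N)nc12`: 100 nM in a functional assay on IMR-32 cells with melanin-concentrating hormone receptor 1 (Homo sapiens) as the target, read by fluorescence; on this read-out lower numbers stand for stronger inhibition and higher numbers for weaker inhibition
Compound 2 `CC(C)c1ccc(C(=O)NCCCOc2cccc3ccc(N)nc23)cc1`: 140 nM in this assay
Compound 3 `COc1cccc(C(=O)NCCCOc2cccc3ccc(N)nc23)c1`: 30 nM in this assay

Among the three measured compounds, compound 3 gives the lowest number in this assay. The nearest is compound 1, the furthest compound 2, and both gaps lie beyond the usual scatter, so compound 3 counts as the most potent of the three. Compound 4, `N#Cc1cccc(C(=O)NCCCOc2cccc3ccc(N)nc23)c1`, differs from compound 3 in one place: cyano in place of methoxy on an aromatic carbon. Among the compounds with values here, only one measured step speaks to a swap of the group on that phenyl ring, a 4.7-fold lower number from compound 2 to compound 3 (0.67 log units; beyond the scatter), and it shows that exchanging one group for another on this ring moves the number modestly rather than dramatically. Within the data shown here, no measured compound carries a cyano group, so there is no direct guide to what it does here; the move from a methoxy to a cyano keeps the count of heavy atoms and of hydrogen-bond acceptors unchanged. The change is therefore expected to shift the number only a little, with a slight weakening as the more likely direction, giving a 1.7-fold higher number from compound 3 to compound 4 (0.22 log units; within the scatter). Compound 4 is estimated at 50 nM, within a range from 15 nM to 200 nM.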

Compound 4, half-maximal inhibitory concentration: 7 nM
Beside the measured number, compound 4's estimate is 7.1-fold (0.85 log units) above it; measured number below the stated range.
By their numbers in this assay, from the lowest: compound 4; then compound 3; then compounds 1 and 2 (each within the scatter of the next).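

Swapping methoxy for cyano on the aromatic carbon meta to a large group gives a 4.3-fold lower number from compound 3 to compound 4 (0.63 log units; beyond the scatter) in this assay, so this one position can move the number beyond the scatter even when the two groups match in heavy atoms and hydrogen-bond acceptors. Seen against the earlier ring change, the 3-cyanophenyl group in place of 4-isopropylphenyl gives a 20-fold lower number from compound 2 to compound 4 (1.30 log units; beyond the scatter), the only large step so far, which shows that the group on this ring can shift the number much further than the earlier step suggested. Nothing measured here accounts for the difference between cyano and methoxy at this position.

On these data alone, it remains open whether the gain belongs to cyano alone or would also appear with a halogen such as chlorine, a trifluoromethyl group, an amine or a carboxylic acid at the same position. Also unsettled is whether the cyano group would give a similar number as 4-cyanophenyl, or whether the step would hold up on a longer chain leading to the shared core.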